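Triazole aryl swap on a weak core: pyridyl to methoxyphenyl

The compounds below may be only part of what the source reports. "The series", "measured", "known", "first", "only" and "open" are said of these compounds alone.

Compound 1 `C=C1C[C@]23C[C@@]1(O)CC[C@H]2c1ccc(O)c(C)c1[C@@H]3Cn1cc(-c2ccccn2)nn1` is followed in a functional assay on SW480 cells (Homo sapiens) for cytotoxicity, read by MTT assay, with a stated time of 4 days; on this read-out higher numbers stand for weaker inhibition and lower numbers for stronger inhibition; here compound 1 gives only a limit, > 20000 nM, and no number. Its bromo analogue compound 2 `C=C1C[C@]23C[C@@]1(O)CC[C@H]2c1cc(Br)c(O)c(C)c1[C@@H]3Cn1cc(-c2ccccn2)nn1` likewise returns a limit in this assay, > 20000 nM. Among the measured compounds shown here, the step that the two limits leave unreadable from compound 1 to compound 2 therefore cannot be read, and the only evidence on the series is the limit of > 20000 nM in this assay, at which 2 of the 2 values shown sit, which places compound 1 at the limit with no measured step above or below it.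

Compound 3 `C=C1C[C@]23C[C@@]1(O)CC[C@H]2c1ccc(O)c(C)c1[C@@H]3Cn1cc(-c2ccc(OC)cc2)nn1` carries the change (4-methoxyphenyl in place of pyridin-2-yl on an aromatic carbon), in words 4-methoxyphenyl in place of pyridin-2-yl on an aromatic carbon of the triazole. For the measured compounds named here, no measured step bears on this exchange: the bromo step from compound 1 to compound 2 touches the phenol ring, not the triazole substituent, and is itself unreadable. With compound 1 at the limit, no direction can be derived, and the expectation is that compound 3 stays within the scatter of compound 1, most likely again as a limit in this assay. The estimate for compound 3 is 30000 nM, in the range 8000 nM to 120000 nM, corresponding to an expected step that the limit leaves unreadable from compound 1 to compound 3 that is not beyond the scatter.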

Compound 3, half-maximal inhibitory concentration: > 20000 nM
Compound 3 was reported as a limit; the forecaster's own chance of this, stated with the estimate: 75%; the middle value does not contradict the limit.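

In this assay, among the compounds shown here, compound 3 is a limit, > 20000 nM, and compound 1 is a limit too, so no step from compound 1 to compound 3 can be read. The series sits at one value: the limit of > 20000 nM in this assay, at which 3 of the 3 values shown sit.

The compounds shown leave open whether any change to the shared core gives a measurable value in this assay.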